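Cytotoxicity of rhodanine-type acids: a carboxybenzyl variant

The source may hold more compounds than are shown below. What is called first, only, known or untested is meant among the compounds shown, and "the series" means these compounds.

Measured so far in an ADME assay on MT2 cells (Homo sapiens) for cytotoxicity, read by XTT assay, with a stated time of 4 days; on this read-out lower numbers stand for higher toxicity in this test and higher numbers for lower toxicity in this test:
- compound 1, `Cc1cc(/C=C2\SC(=S)N(c3ccccc3)C2=O)c(C)n1-c1ccc(O)c(C(=O)O)c1`: > 100000 nM
- compound 2, `Cc1cc(/C=C2\SC(=S)N(Cc3ccc(Br)cc3)C2=O)c(C)n1-c1ccc(O)c(C(=O)O)c1`: 94400 nM
- compound 3, `Cc1cc(/C=C2\SC(=S)N(Cc3ccc(C(C)(C)C)cc3)C2=O)c(C)n1-c1ccc(O)c(C(=O)O)c1`: 55200 nM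

Compound 1 stands at the limit of > 100000 nM in this assay, at which 1 of the 3 values shown sits; its reading is a limit of the assay and not a number. Compound 2 sits at 94400 nM in this assay, and compound 3 at 55200 nM. The step of an at least 1.0-fold lower number from compound 1 to compound 2 (0.02 log units; that floor lies within the scatter) and the step of an at least 1.8-fold lower number from compound 1 to compound 3 (0.25 log units; that floor lies within the scatter) both carry only a floor that lies within the scatter, and the step of a 1.7-fold lower number from compound 2 to compound 3 (0.23 log units; within the scatter) is within the scatter as well, so the three measured compounds show no real spread in this assay.

Compound 4, `Cc1cc(/C=C2\SC(=S)N(Cc3cccc(C(=O)O)c3)C2=O)c(C)n1-c1ccc(O)c(C(=O)O)c1`, is not yet measured. It differs from compound 1 by 3-carboxybenzyl in place of phenyl on an amide-type nitrogen in a ring. The two measured steps that bear on it, both of which also put a benzyl-type group in place of phenyl on that nitrogen, stayed within the scatter, so no step beyond the scatter is expected in this assay for compound 4. The step of a number no higher from compound 1 to compound 4 (the limit leaves the size open) is the estimate that follows. Compound 4 is therefore expected to come out near 100000 nM, with a range from 50000 nM to 200000 nM, and a fair chance that only a limit is reported.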

Compound 4, half-maximal cytotoxic concentration: > 100000 nM
Compound 4: only a limit was reported; the forecaster's own chance of this, stated with the estimate: 55%; the middle value sits exactly at the limit.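

In this assay compound 4 gives > 100000 nM, which is a limit of the assay and not a number, so this position on the amide-type nitrogen takes a 3-carboxybenzyl group with no cytotoxic concentration read out. The step from compound 1 cannot be read, as both of its ends are limits, while the change to 3-carboxyphenyl on the saturated chain carbon gives an at least 1.8-fold higher number from compound 3 to compound 4 (0.25 log units; that floor lies within the scatter) and an at least 1.0-fold higher number from compound 2 to compound 4 (0.02 log units; that floor lies within the scatter), so neither comparison goes beyond the usual scatter. What the earlier compounds did not show is that a benzyl-type group at this position can give a limit, as phenyl did, rather than the numbers seen with the 4-bromobenzyl and 4-(tert-butyl)benzyl groups: the limit of > 100000 nM in this assay, at which 2 of the 4 values shown sit.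

The compounds shown leave open what number compound 1 and compound 4 would have if the assay reached further, so any difference between them stays unknown. They also leave open whether a plain benzyl group, or a benzyl group carrying an amine in place of the carboxylic acid, would likewise give only a limit.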